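Removing the Methoxy Group: Expected Whole-Animal Toxicity

This account rests on a few compounds, and the source may have more. Where it says the series, first, only, none or still open, it means among the compounds named here.

Of the compounds shown here, three built on one shared core have been tested in a toxicity assay on the whole organism (strain Icem-CET (SPF Caw)) for cytotoxicity, with Mus musculus as the target; on this read-out higher numbers stand for an effect only at larger amounts of compound and lower numbers for an effect already at smaller amounts. Compound 1 `C=CCNC(=O)/C(C)=C(\C)c1ccc(OC)cc1` gives 300 mg/kg in this assay. Compound 3 `COc1ccc(/C(C)=C(\C)C(=O)NC2CC2)cc1` gives 300 mg/kg. For compound 2 `C/C(C(=O)NC1CC1)=C(/C)c1ccc(Cl)cc1` this assay reports only a limit, > 800 mg/kg, and not a number. Compound 1 therefore stands level with compound 3, its nearest neighbour, while the remaining value is the limit of > 800 mg/kg in this assay, at which 1 of the 3 values shown sits.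

Two measured steps connect these compounds. Going by the values given here, the first is no change at the digits printed from compound 1 to compound 3 (within the scatter). The second is an at least 2.6-fold lower number from compound 2 to compound 3 (0.42 log units; beyond the scatter).

Compound 4 `C=CCNC(=O)/C(C)=C(\C)c1ccccc1` has not yet been measured. Compared with compound 1 the change is hydrogen in place of methoxy on an aromatic carbon. Neither measured step repeats this change. The step from compound 1 to compound 3 alters the amide side, far from the aromatic carbon in question, and showed nothing beyond the scatter. The step from compound 2 to compound 3 concerns the same aromatic carbon, but swaps one group for another rather than removing it, and its size was at least modest. An exchange at this carbon can thus move the number, in an unknown direction here. Compound 4 is expected to give 400 mg/kg, between 150 mg/kg and 800 mg/kg. This estimate means a 1.3-fold higher number from compound 1 to compound 4 (0.12 log units; within the scatter), an expected step close to none beyond the scatter.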

Compound 4, dose for half-maximal effect: 300 mg/kg
The estimate for compound 4 lay 1.3-fold (0.12 log units) above the measured number; the measured number falls inside the stated range.
By their numbers in this assay, from the lowest: compounds 1, 3 and 4 (each within the scatter of the next). At a limit, above all of these: compound 2.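

In this assay, hydrogen in place of methoxy on this aromatic carbon, para to a large group, gives no change at the digits printed from compound 1 to compound 4 (within the scatter). Going by these compounds alone, the earlier compounds showed this carbon only with one group exchanged for another, so this is the first view of what happens when the substituent is simply taken away, and with the allyl amide the methoxy group proves dispensable for this number. Compound 2, which carries chloro at this carbon, is the only compound that stands apart from the others, and its value is a limit: the limit of > 800 mg/kg in this assay, at which 1 of the 4 values shown sits.

Within the data shown here, the one step at this carbon that goes beyond the scatter, an at least 2.6-fold lower number from compound 2 to compound 3 (0.42 log units; beyond the scatter), was read with the cyclopropyl amide, and it remains open whether chloro would have a similar effect with the allyl amide or whether hydrogen would leave the number unchanged with the cyclopropyl amide. The compounds shown also leave open how an amine, a carboxylic acid or a longer chain such as butoxy at this carbon would behave in this assay.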